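Dropping One Ethynyl Group: What to Expect for Compound 3

This account rests on a few compounds, and the source may have more. Where it says the series, first, only, none or still open, it means among the compounds named here.

Measured compounds:
Compound 1 `C#Cc1nc(-c2ccccc2)cn1C#C`: 2500 nM
Compound 2 `C#Cc1nc(-c2ccc(F)cc2)cn1C#C`: 2600 nM

In a functional assay on A549 cells (Homo sapiens) for cytotoxicity, read by resazurin assay, with a stated time of 72 h (on this read-out higher numbers stand for weaker inhibition and lower numbers for stronger inhibition), compound 1 gives 2500 nM. Going by the values given here, its only neighbour is compound 2, and the step of a 1.0-fold higher number from compound 1 to compound 2 (0.02 log units; within the scatter) shows that the two numbers cannot be told apart. Compound 3 `C#Cn1cnc(-c2ccccc2)c1` is built from compound 1 by a different change: hydrogen in place of ethynyl on an aromatic carbon. Among the compounds with values here, no measured step touches this ethynyl group; the one step recorded alters the six-atom group instead, so it says nothing about the change at hand. The expectation therefore rests on compound 1 alone, with wide uncertainty. Compound 3 is estimated at 4000 nM (range 1500 nM to 12000 nM), a step of a 1.6-fold higher number from compound 1 to compound 3 (0.20 log units; within the scatter) that is expected to run toward weaker inhibition but could fall within the scatter.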

Compound 3, half-maximal inhibitory concentration: 1100 nM
For compound 3 the middle estimate is 3.6-fold (0.56 log units) above the measured one, and the stated range ends above it.
By their numbers in this assay, from the lowest: compound 3; then compounds 1 and 2 (each within the scatter of the next).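

In this assay, putting hydrogen in place of ethynyl on the aromatic carbon between two ring nitrogen atoms gives a 2.3-fold lower number from compound 1 to compound 3 (0.36 log units; beyond the scatter), a modest move toward stronger inhibition. Going by these compounds alone, this is the first change at this position, and it shows that the ethynyl group here is not required for activity in these cells, since compound 3 inhibits more strongly without it. Nothing available explains this gain.

Going by these compounds, whether a small group such as methyl or an amine at this position would match hydrogen remains open. So does the role of the ethynyl group that compound 3 retains.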